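The compounds below may be only part of what the source reports. "The series", "measured", "known", "first", "only" and "open" are said of these compounds alone.

Compound 3 `CN1CCN(c2cccc3c2C[C@H](CN(C)[C@H]2CCCc4cccnc42)NC3)CC1` stands among three compounds whose results in a functional assay on CCRF-CEM cells for agonist activity at C-X-C chemokine receptor type 4 (Homo sapiens), read by calcium flux, with a stated time of 25 min (on this read-out higher numbers stand for an effect only at larger amounts of compound and lower numbers for an effect already at smaller amounts), are all limits of the assay rather than numbers. In this assay compound 3 gives > 30000 nM, which is a limit. Compound 1 `CC(C)N1CCN(c2cccc3c2C[C@H](CN(C)[C@H]2CCCc4cccnc42)NC3)CC1` gives > 30000 nM in this assay, also a limit. Compound 2 `CN(C[C@H]1Cc2c(cccc2N2CCN(c3cccc(C(F)(F)F)c3)CC2)CN1)[C@H]1CCCc2cccnc21` gives > 30000 nM in this assay, again a limit. The steps among them, a step that the two limits leave unreadable from compound 1 to compound 2, a step that the two limits leave unreadable from compound 1 to compound 3 and a step that the two limits leave unreadable from compound 2 to compound 3, cannot be sized, since (the limit of > 30000 nM in this assay, at which 3 of the 3 values shown sit). Compound 4 `CN(C[C@H]1Cc2c(cccc2N2CCN(c3ccccn3)CC2)CN1)[C@H]1CCCc2cccnc21` differs from compound 3 in one place: pyridin-2-yl in place of methyl on an amine nitrogen in a ring. The measured steps all change the group on this same ring nitrogen, from isopropyl to methyl and to 3-(trifluoromethyl)phenyl, and none of them yielded a readable value. Compound 4 is therefore expected to stay at the limit as well, with an estimated step of a number no higher from compound 3 to compound 4 (the limit leaves the size open). For compound 4 the expected value in this assay is 30000 nM, within a range from 10000 nM to 100000 nM.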

Compound 4, half-maximal effective concentration: > 30000 nM
Compound 4 was reported as a limit; the forecaster's own chance of this, stated with the estimate: 75%; the middle value sits exactly at the limit.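

In this assay compound 4 gives > 30000 nM, which is a limit, so its steps from compound 1, compound 2 and compound 3 cannot be read: the limit of > 30000 nM in this assay, at which 4 of the 4 values shown sit. The compounds shown leave open whether any group on this amine nitrogen in a ring gives a readable value.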